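From compound 2 to compound 3: losing one methyl

The source may report more compounds than this note shows. Statements on the series, on what has been measured and on what is new or still open speak of the compounds shown alone.

Of the compounds shown here, two have been measured so far in a functional assay on the whole organism for antagonist activity, with Mus musculus as the target (on this read-out lower numbers stand for an effect already at smaller amounts and higher numbers for an effect only at larger amounts of compound), and both carry a chlorinated core. There compound 1 `CC(=O)NCC(=O)Nc1ccc(Cl)cc1C(=O)c1ccccc1` gives 37 mg/kg while compound 2 `CC(=O)NCC(=O)N(C)c1ccc(Cl)cc1C(=O)c1ccccc1Cl` gives 2.3 mg/kg as its half-maximal dose. Compound 2 therefore holds the lower of the two numbers, and its gap to compound 1 lies well beyond the scatter. The two differ in more than one place, so that gap cannot be pinned on any single change.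

Compound 3 `CC(=O)NCC(=O)Nc1ccc(Cl)cc1C(=O)c1ccccc1Cl` has yet to be measured. It departs from compound 2 by one change, hydrogen in place of methyl on an amide-type nitrogen with hydrogen in place of methyl on an amide-type nitrogen. Within the data shown here, no measured pair shows this change alone, which leaves the size of the step uncertain. Among the measured compounds shown here, the only other reference is compound 1 at 37 mg/kg on the higher side, so a move towards a higher number is expected in this assay rather than a lower one. The expected step is a 2.6-fold higher number from compound 2 to compound 3 (0.42 log units; beyond the scatter) and it is estimated to be modest, just beyond the scatter and well short of the gap between the measured pair. For compound 3 the expected value is 6 mg/kg with an estimated range from 1.5 mg/kg to 22 mg/kg on this read-out.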

Compound 3, dose for half-maximal effect: > 100 mg/kg
Compound 3: a limit, no number; the forecaster's own chance of this, stated with the estimate: 5%; at least 16-fold (1.22 log units) between middle value and limit.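

In this assay, among these compounds, the methyl on the amide-type nitrogen now has a step of its own, and hydrogen in its place gives an at least 43-fold higher number from compound 2 to compound 3 (1.63 log units; beyond the scatter) with the rest of the structure unchanged, the first single change that can be read at this position. With hydrogen on that nitrogen, chloro in place of hydrogen on an aromatic carbon gives an at least 2.7-fold higher number from compound 1 to compound 3 (0.43 log units; beyond the scatter) in the same assay, so in this pair the added chloro brings no move towards a lower number. On these data alone, compound 3 is recorded as a limit and not a number, so both steps give only a least size and their true sizes stay unknown: the limit of > 100 mg/kg in this assay, at which 1 of the 3 values shown sits.

Whether the chloro step would read the same with methyl on the nitrogen stays open, as the compounds shown include no partner for compound 2 that carries hydrogen in place of that chloro. They also do not tell how an ethyl group or a longer chain on that nitrogen would read, or how fluoro would read in place of the chloro.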